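Extending the Chain of Compound 1

The compounds below may be only part of what the source reports. "The series", "measured", "known", "first", "only" and "open" are said of these compounds alone.

In a functional assay on DU-145 cells (Homo sapiens) for inhibition, read by MTT assay, with stated times of 18 h and 4 h (on this read-out lower numbers stand for stronger inhibition and higher numbers for weaker inhibition), compound 1 (`CCCCCCCCCCOP(=O)(O)OCCSC(=S)N1CCCC1`) gives 46100 nM. Compound 2 (`CCCCCCCCCCOP(=O)(O)OCCSC(=S)N1CCCCC1`) gives 29300 nM, and the swap of ring groups shows a 1.6-fold lower number from compound 1 to compound 2 (0.20 log units; within the scatter), so these two values stand level. Compound 3 (`CCCOP(=O)(O)OCCSC(=S)N1CCCC1`) reports only a limit, > 100000 nM.

Shortening the chain of compound 1 gives an at least 2.1-fold higher number from compound 1 to compound 3 (0.33 log units; beyond the scatter), and this is the only measured step that alters chain length. On these data alone, its true size is unknown, since one end of it is a limit. Compound 4 (`CCCCCCCCCCCCCCCCOP(=O)(O)OCCSC(=S)N1CCCC1`) changes that same chain in the opposite direction, with hexyl in place of hydrogen on a saturated chain carbon, ten or more bonds along the chain from an oxygen on an unsaturated carbon. With a single step to go on, a longer chain is expected to lower the number modestly in this assay, though a result within the scatter would be no surprise. An estimated step of a 2.3-fold lower number from compound 1 to compound 4 (0.36 log units; beyond the scatter) is therefore expected. The expected value for compound 4 is 20000 nM, with an estimated range from 7000 nM to 60000 nM.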

Compound 4, half-maximal inhibitory concentration: 28900 nM
The estimate for compound 4 lay 1.4-fold (0.16 log units) below the measured number, and the stated range covers the measured number.
By their numbers in this assay, from the lowest: compounds 4, 2 and 1 (each within the scatter of the next). At a limit, above all of these: compound 3.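

Adding hexyl on a saturated chain carbon gives a 1.6-fold lower number from compound 1 to compound 4 (0.20 log units; within the scatter) in this assay, so the two compounds stand level. The earlier compounds shown here showed only that shortening this chain moves the number beyond the scatter, whereas this result shows that lengthening it brings no measurable gain. Compound 3 remains a limit, so the full size of the loss on shortening cannot be read: the limit of > 100000 nM in this assay, at which 1 of the 4 values shown sits.

On these data alone, it remains open how short the chain can become, compared with that of compound 1, before the number rises. Also open, as far as these compounds go, is whether a still longer chain, a chain ending in an amine or a carboxylic acid, or the longer chain of compound 4 paired with the piperidin-1-yl group of compound 2 would change the number.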